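Pyridyl amide in place of dimethylaminophenyl amide: compound 4

This account rests on a few compounds, and the source may have more. Where it says the series, first, only, none or still open, it means among the compounds named here.

Measured so far in a functional assay on HEK293 cells for antagonist activity at metabotropic glutamate receptor 5 (Homo sapiens), read by FLIPR and calcium flux; a lower number here means a stronger inhibitor, a higher number a weaker inhibitor:
compound 1 `CN(C)c1ccc(C(=O)N[C@H]2CCC[C@H](NC(=O)c3cccc(Cl)c3)C2)cc1` gives 473 nM
compound 2 `N#Cc1cccc(C(=O)N[C@H]2CCC[C@H](NC(=O)c3ccccn3)C2)c1` gives a limit, > 10000 nM
compound 3 `Cc1cccc(C(=O)N[C@H]2CCC[C@H](NC(=O)c3ccccn3)C2)c1` gives 1000 nM

Compound 1 holds the lowest of the two numbers read in this assay; compound 3 sits a little above it, a gap beyond the scatter. Compound 2 reports only a limit of this assay, (the limit of > 10000 nM in this assay, at which 1 of the 3 values shown sits), and no number.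

Compound 4 `O=C(N[C@H]1CCC[C@H](NC(=O)c2cccc(Cl)c2)C1)c1cccnc1` keeps the core of compound 1 and its chlorophenyl amide, but changes the other amide: pyridin-3-yl in place of 4-(dimethylamino)phenyl on a carbonyl carbon. Among the compounds with values here, no measured pair makes this same exchange. Within the data shown here, the one measured step, an at least 10-fold lower number from compound 2 to compound 3 (1.00 log units; beyond the scatter), concerns a substituent on a phenyl amide and not the aryl group itself, so it bears only indirectly. What the numbers do show is that a pyridyl amide in the series is compatible with a measurable value, as compound 3 shows at 1000 nM, and that a small change on the aryl amide can move the read-out by a large amount, as the step from compound 2 to compound 3 shows.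

The expectation for compound 4 in this assay is therefore a somewhat weaker inhibitor than compound 1, estimated at 1000 nM, with a range from 250 nM to 4000 nM, an expected step of a 2.1-fold higher number from compound 1 to compound 4 (0.33 log units; beyond the scatter).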

Compound 4, half-maximal inhibitory concentration: 612 nM
Compound 4: the middle estimate sits 1.6-fold (0.21 log units) above what was measured, and the stated range covers the measured number.
By their numbers in this assay, from the lowest: compounds 1, 4 and 3 (each within the scatter of the next, the first and the last beyond it). At a limit, above all of these: compound 2.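

In this assay, the exchange of 4-(dimethylamino)phenyl for pyridin-3-yl on a carbonyl carbon gives a 1.3-fold higher number from compound 1 to compound 4 (0.11 log units; within the scatter) with the chlorophenyl amide held constant, so this pair shows no separation between the two aryl groups. The earlier compounds shown here bore only on a substituent of a phenyl amide, whereas this pair changes the aryl group itself: at this position, neither the dimethylamino group nor an all-carbon ring is required for a value in the same range as that of compound 1. No measurement shown gives a cause for this outcome, and the two parts of the exchange, loss of the dimethylamino group and a ring nitrogen in place of carbon, remain joined in this single step.

An unsubstituted phenyl group on the same carbonyl carbon would be needed to separate those two parts of the exchange. On these data alone, it also remains open whether this position accepts a ring carrying a carboxylic acid, or a saturated amine such as piperidine in place of the aromatic ring, with the same lack of separation from compound 1.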